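Swapping the aryl group on the sulfonyl of compound 1

The source may hold more compounds than are shown below. What is called first, only, known or untested is meant among the compounds shown, and "the series" means these compounds.

Measured compounds:
- compound 1, `CC1CCN(c2c(S(=O)(=O)c3cccc(Cl)c3)cnc3ccc(Cl)cc23)CC1`: 92%
- compound 2, `Cc1ccc(S(=O)(=O)c2cnc3cc(Cl)ccc3c2N2CCC(C)CC2)cc1C`: 86%
- compound 3, `Cc1ccc(S(=O)(=O)c2cnc3ccc(F)cc3c2N2CCC(C)CC2)cc1Cl`: 91%

All three compounds share one core and carry a methylpiperidine on it; they differ in the aryl group attached to the sulfonyl sulfur. In an assay on isolated protein for displacement of a labelled ligand from metabotropic glutamate receptor 5 (Homo sapiens), with a stated time of 60 min, tested at 1 uM (on this read-out lower numbers stand for less inhibition and higher numbers for more inhibition at the one concentration tested (going by the name of the read-out)), compound 1 gives 92%. Compound 3 gives 91% and compound 2 gives 86%. Compound 1 has the highest number of the three, but both other values sit within the usual scatter of it, so no order among them can be read from these data. What the set does show is that the aryl group on the sulfonyl can be varied across the three compounds while the inhibition stays high.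

Compound 4, `CC1CCN(c2c(S(=O)(=O)c3ccc(F)cc3)cnc3ccc(Cl)cc23)CC1`, has not yet been measured. It differs from compound 1 in one place: 4-fluorophenyl in place of 3-chlorophenyl on a sulfonyl sulfur. For the measured compounds named here, no measured pair with this exact change exists, so the expectation rests on the three values above, whose numbers lie level with one another, within the scatter, across the three aryl groups. The step from compound 1 to compound 4 is expected to be small, a number 7 percentage points lower from compound 1 to compound 4 (within the scatter), and no larger than the scatter. Compound 4 is therefore estimated at 85%, with a range from 68% to 96%.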

Compound 4, a percentage reported as inhibition, at one concentration (the size of the read-out at that concentration, not a potency): 89%
Compound 4: middle estimate off by 4 percentage points, on the low side; the measured number falls inside the stated range.
By their numbers in this assay, from the lowest: compounds 2, 4, 3 and 1 (each within the scatter of the next).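

For the compounds shown here, this is the first pair in the set that differs in one place only, so the effect of the aryl group can be read directly, without other parts of the molecule changing alongside it. In this assay, putting 4-fluorophenyl in place of 3-chlorophenyl on a sulfonyl sulfur gives a number 3 percentage points lower from compound 1 to compound 4 (within the scatter) and so leaves inhibition level with that of the parent compound, which means this position accepts a change of both the halogen and its place on the phenyl ring without a measurable loss at this single concentration. No measurement given here offers an explanation for this result.

Because both halogens were exchanged and moved in one step, the effect of each change alone stays unresolved, and with every value near the top of the scale, these numbers cannot separate the compounds by potency. Going by these compounds, it also remains open whether inhibition would hold with an amine or a carboxylic acid on that phenyl ring, or with a simple methyl group in place of the whole aryl group on the sulfonyl sulfur.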